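From a chlorophenyl to a dimethoxyphenyl group

The source may hold more compounds than are shown below. What is called first, only, known or untested is meant among the compounds shown, and "the series" means these compounds.

compound 1 `O=C1C(=Cc2ccc(Cl)cc2)C(=O)N(c2ccc(Cl)cc2)N1c1ccc(Cl)cc1` gives 17300 nM
compound 2 `O=C1C(=Cc2cccc(Cl)c2)C(=O)N(c2ccc(Cl)cc2)N1c1ccc(Cl)cc1` gives 22600 nM

Among the measured compounds shown here, both numbers come from a functional assay on ECa-109 cells (Homo sapiens) for cytotoxicity, read by MTT assay, with a stated time of 72 h (on this read-out lower numbers stand for stronger inhibition and higher numbers for weaker inhibition), and are the only measurements so far. Compound 2 and compound 1 cannot be told apart on these numbers, since they lie within the usual scatter of repeated measurements of each other. For the measured compounds named here, the single measured step is a 1.3-fold higher number from compound 1 to compound 2 (0.12 log units; within the scatter) and it only moves the chlorine around the same phenyl ring.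

Compound 3 `COc1ccc(C=C2C(=O)N(c3ccc(Cl)cc3)N(c3ccc(Cl)cc3)C2=O)cc1OC` brings a different kind of change at that same place, 3,4-dimethoxyphenyl in place of 3-chlorophenyl on a double-bonded chain carbon bound to a double-bonded ring carbon while the shared core stays as it is. Going by the values given here, no measured compound carries a dimethoxyphenyl group, so nothing shows directly what this swap does. Among the compounds with values here, the only guide is a 1.3-fold higher number from compound 1 to compound 2 (0.12 log units; within the scatter) and on that evidence no step beyond the scatter is expected in this assay although the range has to stay wide. The expected size of the change is a 1.1-fold lower number from compound 2 to compound 3 (0.05 log units; within the scatter) as an estimate from this one step. For compound 3 the estimated value is 20000 nM with an expected range from 7000 nM to 60000 nM for repeated measurements.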

Compound 3, half-maximal inhibitory concentration: > 128000 nM
Compound 3: only a limit was reported (the forecaster's own chance of this, stated with the estimate: 10%); middle value at least 6.4-fold (0.80 log units) from the limit.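

Compound 3 gave no number in this assay, only a limit: the limit of > 128000 nM in this assay, at which 1 of the 3 values shown sits. Among the compounds shown here, that limit still shows what compound 1 and compound 2 could not, namely that this place on a double-bonded chain carbon bound to a double-bonded ring carbon does respond to what it carries, since the only earlier step, a 1.3-fold higher number from compound 1 to compound 2 (0.12 log units; within the scatter), merely moved the chlorine around the ring. From the compounds shown here alone, replacing the chlorophenyl groups with 3,4-dimethoxyphenyl gives an at least 5.6-fold higher number from compound 2 to compound 3 (0.75 log units; beyond the scatter) and an at least 7.3-fold higher number from compound 1 to compound 3 (0.86 log units; beyond the scatter), so inhibition of these cells becomes clearly weaker, though the true size of the loss stays unknown.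

The compounds shown cannot separate the effect of having two methoxy groups from that of removing the chlorine, or from the change from 7 to 10 heavy atoms in the group, as all of these arrive together in compound 3. A phenyl ring carrying a single methoxy group, a hydroxyl group or an amine at this place would be needed to tell whether the loss belongs to the dimethoxy pair or extends to other groups.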